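Inverting One Stereocentre of Compound 1

This account rests on a few compounds, and the source may have more. Where it says the series, first, only, none or still open, it means among the compounds named here.

In a functional assay on A549 cells (Homo sapiens) for cytotoxicity, read by MTT assay, with a stated time of 48 h (a higher number here means a weaker inhibitor, a lower number a stronger inhibitor), compound 1 (`COc1cc([C@@H]2C[C@@]2(CO)C(=O)Nc2ccccc2)cc(OC)c1OC`) gives 43200 nM. Compound 2 (`COc1cc([C@@H]2C[C@@]2(CO)C(=O)NCc2ccc(C)cc2)cc(OC)c1OC`) gives 46300 nM, and compound 3 (`CCOC(=O)[C@@]1(C(=O)Nc2ccccc2)C[C@H]1c1cc(OC)c(OC)c(OC)c1`) gives 65900 nM. Compound 1 thus stands level with both of the others. With 4-methylbenzyl in place of phenyl on an amide-type nitrogen, the step is a 1.1-fold higher number from compound 1 to compound 2 (0.03 log units; within the scatter). With ethoxycarbonyl in place of hydroxymethyl on a saturated ring carbon, it is a 1.5-fold higher number from compound 1 to compound 3 (0.18 log units; within the scatter).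

Going by the values given here, compound 4 (`COc1cc([C@@H]2C[C@]2(CO)C(=O)Nc2ccccc2)cc(OC)c1OC`) has no measurement yet. Its relation to compound 1 is as follows: the two compounds have the same atoms and bonds and differ only in configuration as drawn: 1 of 2 stereo elements differ; a stereocentre at a saturated ring carbon is drawn R in compound 1 and S in compound 4. Among the compounds with values here, neither measured step alters configuration, and the data contain no measured pair of stereoisomers, so neither step gauges this change directly. Within the data shown here, they show only that two exchanges of groups on compound 1 stayed within the scatter, and they give no direction for an inversion. A step beyond the scatter is therefore not expected, although this rests on indirect evidence and the range is kept wide on both sides. The expected step, an estimate only, is a 1.2-fold higher number from compound 1 to compound 4 (0.06 log units; within the scatter). Compound 4 is estimated at 50000 nM, with an expected range from 22000 nM to 105000 nM.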

Compound 4, half-maximal inhibitory concentration: 24100 nM
Estimate against measurement, compound 4: 2.1-fold (0.32 log units) above; low and high end bracket the measured number.
By their numbers in this assay, from the lowest: compounds 4, 1, 2 and 3 (each within the scatter of the next, the first and the last beyond it).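

In this assay, going by these compounds alone, the inversion gives the first direct reading of configuration at this saturated ring carbon: a 1.8-fold lower number from compound 1 to compound 4 (0.25 log units; within the scatter). The two earlier steps exchanged groups, whereas this pair leaves every atom and bond in place and so reads the stereocentre alone: the fact that compounds 1 and 4 differ only in the configuration as drawn. The inversion thus joins the two exchanges of groups as a third change on compound 1 that stays within the scatter, so in this one pair the configuration drawn at this carbon does not separate the two compounds beyond it.

The compounds shown leave open whether the same inversion would read alike with 4-methylbenzyl on the amide-type nitrogen or with ethoxycarbonyl on the saturated ring carbon, and what a change at the other stereo element of compound 1 would do. Also open, on these data alone, is whether a carboxylic acid or an amine in place of hydroxymethyl on that ring carbon would give a step beyond the scatter in either configuration.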